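The source may hold more compounds than are shown below. What is called first, only, known or untested is meant among the compounds shown, and "the series" means these compounds.

Going by the values given here, compound 1 `COc1cc(/C=C2\CN(C)C/C(=C\c3ccc(Br)cc3)C2=O)cc(OC)c1OC` carries a 4-bromophenyl and is the one member of this set whose result comes out as a number. In a functional assay on K562 cells (Homo sapiens) for cytotoxicity, read by MTT assay, with a stated time of 24 h (a lower number here means a stronger inhibitor, a higher number a weaker inhibitor), compound 1 gives 12400 nM. Compound 2 `COc1cc(/C=C2\CN(C)C/C(=C\c3ccc(Cl)cc3Cl)C2=O)cc(OC)c1OC` differs from compound 1 by a single change, (2,4-dichlorophenyl in place of 4-bromophenyl on a double-bonded chain carbon bound to a double-bonded ring carbon). In this assay compound 2 reaches only a limit of the assay, > 20000 nM, and not a number. The measured step is an at least 1.6-fold higher number from compound 1 to compound 2 (0.20 log units; that floor lies within the scatter), and its size is bounded because of the limit of > 20000 nM in this assay, at which 2 of the 3 values shown sit. Compound 3 `CN1C/C(=C\c2ccc(Br)cc2)C(=O)/C(=C/c2cccc([N+](=O)[O-])c2)C1` keeps the 4-bromophenyl but stands on another core, and the difference between the two cores is not broken down here. In this assay compound 3 likewise gives only a limit, > 20000 nM. Compound 4 `CN1C/C(=C\c2cccc([N+](=O)[O-])c2)C(=O)/C(=C/c2ccc(Cl)cc2Cl)C1` has not yet been measured and differs from compound 3 by the same change, (2,4-dichlorophenyl in place of 4-bromophenyl on a double-bonded chain carbon bound to a double-bonded ring carbon). For compound 4 the expected step is a step that the limit leaves unreadable from compound 3 to compound 4. That expectation rests on compound 3, whose result in this assay is already the limit > 20000 nM. It also rests on the step of an at least 1.6-fold higher number from compound 1 to compound 2 (0.20 log units; that floor lies within the scatter), which carried a numbered result only as far as the limit. The estimated value of compound 4 is therefore 30000 nM, with a likely span from 15000 nM to 80000 nM, and most probably this assay will again report only a limit for it.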

Compound 4, half-maximal inhibitory concentration: 12400 nM
Estimate against measurement, compound 4: 2.4-fold (0.38 log units) above; measured number outside the range, below it.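

Carried onto the core of compound 3, the change from 4-bromophenyl to 2,4-dichlorophenyl gives an at least 1.6-fold lower number from compound 3 to compound 4 (0.20 log units; that floor lies within the scatter). Set beside the earlier step in this assay, this yields neither a fixed size nor a settled direction for the change, and it does not tell whether the two cores respond to it differently: the same change on two cores in this assay, an at least 1.6-fold higher number (0.20 log units; that floor lies within the scatter) from compound 1 to compound 2 and an at least 1.6-fold lower number (0.20 log units; that floor lies within the scatter) from compound 3 to compound 4; the limit leaves it open whether they differ What the results do show is limited: on this core the 2,4-dichlorophenyl compound returns a number and the 4-bromophenyl compound does not, while on the core of compound 1 the reverse holds, and no true size can be given for either step because one end of each rests on a limit: the limit of > 20000 nM in this assay, at which 2 of the 4 values shown sit.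

The compounds shown leave open how either core would behave with a plain phenyl, a fluorophenyl or a phenyl carrying an amine on that same double-bonded chain carbon. They also leave open whether this change would keep one direction on a pair of compounds that both return numbers in this assay, which is the comparison needed to decide whether it carries from one core to another.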